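This account rests on a few compounds, and the source may have more. Where it says the series, first, only, none or still open, it means among the compounds named here.

In an assay on isolated protein for inhibition of matrix metalloproteinase-9 (Homo sapiens) (a lower number here means a stronger inhibitor, a higher number a weaker inhibitor), compound 1 `O=C(OCc1ccccc1)c1cccc(=O)[nH]1` gives 69000 nM. Among the three compounds measured so far it holds the second highest number: compound 2 `O=C(OCc1ccccc1Cl)c1cccc(=O)[nH]1` gives 81000 nM, a step of a 1.2-fold higher number from compound 1 to compound 2 (0.07 log units; within the scatter), while compound 3 `O=C(OCc1ccc(F)cc1)c1cccc(=O)[nH]1` gives 3000 nM, a step of a 23-fold lower number from compound 1 to compound 3 (1.36 log units; beyond the scatter). Compound 4 `O=C(OCc1cccc(Oc2ccccc2)c1)c1cccc(=O)[nH]1` differs from compound 1 by phenoxy in place of hydrogen on an aromatic carbon. Both measured steps also replace hydrogen on an aromatic carbon, but with small groups, and they disagree: chloro stayed within the scatter, fluoro brought a large fall. Phenoxy is far bigger than either, so neither step is a close guide; a modest improvement with wide uncertainty seems most plausible. The expected step is therefore a 3.5-fold lower number from compound 1 to compound 4 (0.54 log units; beyond the scatter). Compound 4 is thus estimated at 20000 nM in this assay, within a range of 3000 nM to 100000 nM.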

Compound 4, half-maximal inhibitory concentration: > 150 nM
Compound 4: no number, only a limit; the forecaster's own chance of this, stated with the estimate: 5%; the middle value is on the limit's open side.
By their numbers in this assay, from the lowest: compound 3; then compounds 1 and 2 (each within the scatter of the next).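

In this assay compound 4 gives > 150 nM, which is a limit and not a number, so the step from compound 1 to compound 4 cannot be read. The compounds shown leave open whether phenoxy in place of hydrogen gives a stronger or a weaker inhibitor than compound 1.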